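This account rests on a few compounds, and the source may have more. Where it says the series, first, only, none or still open, it means among the compounds named here.

Going by the values given here, compound 2 `Cc1ccc(/C=C2\S/C(=N\c3csc(-c4ccc(Cl)cc4)c3)NC2=O)cc1` stands lowest of the two numbers so far measured in a functional assay on HCT-116 cells (Homo sapiens) for cytotoxicity, read by MTT assay, with a stated time of 72 h (a higher number here means a weaker inhibitor, a lower number a stronger inhibitor), where compound 2 gives 1000 nM. Among the compounds with values here, its only measured neighbour, compound 1 `O=C1N/C(=N/c2csc(-c3ccc(Cl)cc3)c2)S/C1=C\c1ccccc1`, gives 11200 nM in this assay, and the step of an 11-fold lower number from compound 1 to compound 2 (1.05 log units; beyond the scatter) goes with a methyl in place of hydrogen on an aromatic carbon. Compound 3 `CN(C)c1ccc(/C=C2\S/C(=N\c3csc(-c4ccc(Cl)cc4)c3)NC2=O)cc1` has not yet been measured. It differs from compound 2 in one place: dimethylamino in place of methyl on an aromatic carbon. The group sits on an aromatic carbon of a six-membered aromatic ring of carbon only, para to a large group, so that 4-methylphenyl becomes 4-(dimethylamino)phenyl. Within the data shown here, the single measured step that touches this position, an 11-fold lower number from compound 1 to compound 2 (1.05 log units; beyond the scatter), was large, and it shows that a substituent at this carbon can be carried without loss. Nothing measured tells how a dimethylamino compares with a methyl at the same carbon. The step of a 1.4-fold lower number from compound 2 to compound 3 (0.15 log units; within the scatter) is therefore expected to stay within, or close to, the scatter. Compound 3 is estimated at 700 nM, with a range from 150 nM to 3500 nM.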

Compound 3, half-maximal inhibitory concentration: 500 nM
Estimate against measurement, compound 3: 1.4-fold (0.15 log units) above, within the range that was stated.
By their numbers in this assay, from the lowest: compounds 3 and 2 (each within the scatter of the next); then compound 1.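

In this assay, the exchange of methyl for dimethylamino on this aromatic carbon gives a 2.0-fold lower number from compound 2 to compound 3 (0.30 log units; within the scatter), so this first direct comparison of two substituents at the position does not separate them. Against hydrogen, dimethylamino gives a 22-fold lower number from compound 1 to compound 3 (1.35 log units; beyond the scatter), a large step that stands beside the one for methyl, an 11-fold lower number from compound 1 to compound 2 (1.05 log units; beyond the scatter), so the gain seen with a single substituent is now seen with a second, larger one, and neither of the two substituted compounds goes against it. No supporting evidence is available to say what lies behind either step.

The compounds shown leave open whether other groups on this carbon, such as a carboxylic acid, a chlorine atom or a longer alkyl chain, would go with numbers like those of compound 2 and compound 3 or like that of compound 1. They also leave open whether dimethylamino would give a similar step on another carbon of the same ring, since both substituents compared here sit at the one position.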